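Amide Replacement and Tolerated Concentration in a Cell Assay

The compounds below may be only part of what the source reports. "The series", "measured", "known", "first", "only" and "open" are said of these compounds alone.

Compound 1 `CC(C)n1ncc2c(C(=O)N3CCc4cc(F)ccc43)cc(-c3cccs3)nc21` gives > 200000 nM in an ADME assay on LLC-MK2 cells (Macaca mulatta) for cytotoxicity, read by spectrophotometry and crystal violet staining, with a stated time of 4 days (a lower number here means that less compound is tolerated, a higher number that more compound is tolerated), which is a limit.
Compound 2 `CC(C)n1ncc2c(C(=O)N3CCc4cccnc43)cc(-c3cccs3)nc21` gives 50000 nM in this assay.
Compound 3 `CC(C)n1ncc2c(C(=O)Nc3ccc(F)cc3)cc(-c3ccco3)nc21` gives > 200000 nM in this assay, also a limit.

Among the three values shown, compound 2 is the only one reported as a number; the other two sit at the limit of > 200000 nM in this assay, at which 2 of the 3 values shown sit. For the measured compounds named here, compound 2 is therefore the least tolerated of the three in this assay, and the only compound from which a numbered step can be followed.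

Compound 4 `CC(C)n1ncc2c(C(=O)Nc3ccncn3)cc(-c3cccs3)nc21` differs from compound 2 in one place: a group of 7 heavy atoms (4 carbon, 3 nitrogen; one six-membered aromatic ring with 2 hetero atoms) in place of a group of 9 heavy atoms (7 carbon, 2 nitrogen; one five-membered non-aromatic ring with 1 hetero atom, one six-membered aromatic ring with 1 hetero atom), on a carbonyl carbon. Going by the values given here, no step between two measured compounds matches this change, so its size can only be expected, not read off. Compound 3, whose carbonyl likewise carries an aromatic amine rather than the fused ring, is reported as a limit in this assay. Taking that as the nearest hint, the account expects the step from compound 2 to compound 4 to run upward, toward greater tolerance, and to exceed the usual scatter: a 3.0-fold higher number from compound 2 to compound 4 (0.48 log units; beyond the scatter). Compound 4 is thus estimated at 150000 nM in this assay, within a range from 40000 nM to 300000 nM, with a fair chance that only a limit is reported.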

Compound 4, half-maximal cytotoxic concentration: 50000 nM
Compound 4: middle estimate off by 3.0-fold (0.48 log units), on the high side; the measured number falls inside the stated range.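

In this assay, the exchange on the carbonyl carbon, where (pyrimidin-4-yl)amino takes the place of the fused two-ring group, leaves the read-out unmoved: no change at the digits printed from compound 2 to compound 4 (within the scatter). For the compounds shown here, this is the first readable step at this position, and it shows that a smaller group with a single six-membered aromatic ring, two hetero atoms in that ring and an amide hydrogen can stand here with the number held level, so an aromatic amine on the carbonyl does not by itself bring a compound to a limit. Only compound 2 and compound 4 carry numbers that can be set side by side, and the remaining values are limits, not numbers: the limit of > 200000 nM in this assay, at which 2 of the 4 values shown sit.

What the compounds shown leave open is whether the level result belongs to the ring nitrogens of the pyrimidine, since a plain phenylamino group on the same thiophene-bearing core does not stand among them. They also leave open how this position responds to a non-aromatic amine such as morpholine or piperidine, or to a simple alkyl amine on the carbonyl.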